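Working notes: phenyl to 2-hydroxyphenyl on compound 1

A few compounds are considered here, and "the series" means these few. Any claim that something is new, unique, unknown or untested is made for them only; others in the source may bear on it.

Of the compounds shown here, three have been read so far in an ADME assay on HEL cells (Homo sapiens) for cytotoxicity (on this read-out higher numbers stand for lower toxicity in this test and lower numbers for higher toxicity in this test), and none of the pairs differs in one place only. Compound 1 (`C/C(=N\NC(=O)COc1cccc2ccccc12)c1ccccc1`) gives 20 ug/mL and stands lowest of the three. Compound 2 (`O=C(COc1cccc2ccccc12)N/N=C/c1cccc([N+](=O)[O-])c1`) gives 61.2 ug/mL and compound 3 (`COc1ccc(/C=N/NC(=O)COc2cccc3ccccc23)cc1OC`) gives 52.6 ug/mL in the same test, and both lie beyond the scatter above compound 1.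

The next compound is compound 4 (`C/C(=N\NC(=O)COc1cccc2ccccc12)c1ccccc1O`), which carries hydroxy in place of hydrogen on an aromatic carbon, ortho to a large group (hydroxy in place of hydrogen on an aromatic carbon). Among the compounds with values here, the series holds no measured precedent for this change, so the expectation starts from compound 1 at 20 ug/mL as its closest measured relative. The expected step of a 1.1-fold higher number from compound 1 to compound 4 (0.04 log units; within the scatter) stays within the scatter, with no direction favoured. For compound 4 the estimate is 22 ug/mL in this test, with an expected range from 8 ug/mL to 70 ug/mL as the likely span of the measurement.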

Compound 4, half-maximal cytotoxic concentration: 4 ug/mL
Estimate against measurement, compound 4: 5.5-fold (0.74 log units) above, and the stated range ends above it.
By their numbers in this assay, from the lowest: compound 4; then compound 1; then compounds 3 and 2 (each within the scatter of the next).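

In this assay, within the data shown here, hydroxy in place of hydrogen on an aromatic carbon, ortho to a large group, gives a 5.0-fold lower number from compound 1 to compound 4 (0.70 log units; beyond the scatter), the first step that changes one place only. This position on the phenyl ring of compound 1 therefore does not leave the read-out unchanged: the single added hydroxy moves it beyond the scatter, towards higher toxicity in this test. Nothing at hand speaks to the reason for this step.

The compounds shown leave open whether this step belongs to hydroxy itself or would also follow from another group at the same place, such as methoxy, fluorine or an amine. Also open, on these data alone, is whether hydroxy gives a step of similar size on a different member of the series, such as compound 3.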